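Phenyl for chloro: expected growth-inhibition step

A few compounds are considered here, and "the series" means these few. Any claim that something is new, unique, unknown or untested is made for them only; others in the source may bear on it.

Three amides sharing one core have been run in a functional assay on U-87MG ATCC cells (Homo sapiens) for inhibition, read by MTT assay, with a stated time of 72 h; on this read-out higher numbers stand for weaker inhibition of growth and lower numbers for stronger inhibition of growth. Compound 1 `O=C(NCc1ccc(-c2ccccc2)cc1)c1ccc[nH]1` gives 11000 nM. Compound 2 `O=C(NCc1ccccc1)c1cc(Br)c(Br)[nH]1` reaches only > 50000 nM, which is the limit of > 50000 nM in this assay, at which 1 of the 3 values shown sits, not a number. Compound 3 `O=C(NCc1ccc(Cl)cc1)c1cc(Br)c(Br)[nH]1` gives 34000 nM, the higher of the two numbers, with compound 1 lower by a margin beyond the scatter.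

Compound 4 `O=C(NCc1ccc(-c2ccccc2)cc1)c1cc(Br)c(Br)[nH]1` differs from compound 3 by phenyl in place of chloro on an aromatic carbon, para to a large group. Among the compounds with values here, the only measured step at that carbon, an at least 1.4-fold lower number from compound 2 to compound 3 (0.16 log units; that floor lies within the scatter), stays within the scatter. Within the data shown here, compound 1 and compound 2 differ in two places, so their values give no single step. Since the phenyl-bearing compound 1 shows the lower number, a modest drop is expected for compound 4, a 1.7-fold lower number from compound 3 to compound 4 (0.23 log units; within the scatter). Compound 4 is estimated at 20000 nM, between 8000 nM and 50000 nM.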

Compound 4, concentration for 50% growth inhibition: > 50000 nM
Compound 4: no number, only a limit; the forecaster's own chance of this, stated with the estimate: 15%; at least 2.5-fold (0.39 log units) between middle value and limit.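

Phenyl in place of chloro on this aromatic carbon, para to a large group, brings no gain in this assay: the change gives an at least 1.4-fold higher number from compound 3 to compound 4 (0.16 log units; that floor lies within the scatter). With the phenyl kept, 4,5-dibromo-1H-pyrrol-2-yl in place of 1H-pyrrol-2-yl on the carbonyl carbon gives an at least 4.5-fold higher number from compound 1 to compound 4 (0.65 log units; beyond the scatter), so the lower number of compound 1 does not carry over to compound 4. Compound 2 and compound 4 both stand at a limit, so the step between them cannot be read: the limit of > 50000 nM in this assay, at which 2 of the 4 values shown sit.

Left open is what an amine or a carboxylic acid in place of chloro on this aromatic carbon would give in compound 3.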